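A few compounds are considered here, and "the series" means these few. Any claim that something is new, unique, unknown or untested is made for them only; others in the source may bear on it.

Of the compounds shown here, three have been measured in a functional assay on HepG2 cells (Homo sapiens) for inhibition, read by MTT assay, with a stated time of 72 h; a higher number here means a weaker inhibitor, a lower number a stronger inhibitor. Compound 1 `Cc1ccccc1-n1cc(COc2cccc(NC(=O)Nc3ccc(Cl)c(C(F)(F)F)c3)c2)nn1` gives 3440 nM, compound 2 `COc1ccc(-n2cc(COc3cccc(NC(=O)Nc4ccc(Cl)c(C(F)(F)F)c4)c3)nn2)cc1` gives 4680 nM, and compound 3 `CCc1ccc(-n2cc(COc3cccc(NC(=O)Nc4ccc(Cl)c(C(F)(F)F)c4)c3)nn2)cc1` gives 1950 nM. Compound 3 holds the lowest of the three numbers; its gap to compound 1 lies within the scatter, whereas a 2.4-fold lower number from compound 2 to compound 3 (0.38 log units; beyond the scatter) is a modest step beyond it. The only variable across the set is the aryl group on the aromatic nitrogen of the shared core.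

Compound 4 `O=C(Nc1cccc(OCc2cn(-c3ccccc3Cl)nn2)c1)Nc1ccc(Cl)c(C(F)(F)F)c1` carries the change (2-chlorophenyl in place of 4-ethylphenyl on an aromatic nitrogen). Among the compounds with values here, two measured steps bear on it. a 1.8-fold lower number from compound 1 to compound 3 (0.25 log units; within the scatter) exchanged 2-methylphenyl for 4-ethylphenyl and stayed within the scatter, so moving a small group from the 2-position back to the 4-position has so far made little difference. a 2.4-fold lower number from compound 2 to compound 3 (0.38 log units; beyond the scatter) exchanged 4-methoxyphenyl for 4-ethylphenyl and gave the only step beyond the scatter. Within the data shown here, no measured compound carries chlorine on this ring, so compound 4 has no direct precedent. Because compound 1 with 2-methylphenyl gives 3440 nM, compound 4 is expected to land near it, and a 1.5-fold higher number from compound 3 to compound 4 (0.19 log units; within the scatter) is expected to remain within the scatter. The estimate for compound 4 is 3000 nM, with a range of 1200 nM to 8000 nM.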

Compound 4, half-maximal inhibitory concentration: 1960 nM
Compound 4: middle estimate off by 1.5-fold (0.18 log units), on the high side; low and high end bracket the measured number.
By their numbers in this assay, from the lowest: compounds 3, 4, 1 and 2 (each within the scatter of the next, the first and the last beyond it).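

Across the aryl groups on the aromatic nitrogen, 2-chlorophenyl and 4-ethylphenyl cannot be told apart in this assay (a 1.0-fold higher number from compound 3 to compound 4 (0.00 log units; within the scatter)), so a chlorine-bearing ring and an alkyl-bearing ring are both tolerated here. Chloro in place of methyl on the same ring also stays inside the scatter (a 1.8-fold lower number from compound 1 to compound 4 (0.24 log units; within the scatter)), so this exchange has no readable effect. The step from 4-methoxyphenyl to 2-chlorophenyl lies beyond the scatter (a 2.4-fold lower number from compound 2 to compound 4 (0.38 log units; beyond the scatter)), which sets compound 2 apart from both compound 3 and compound 4, while compound 1 goes against any clean split by staying within the scatter of compound 2.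

Still open, from the compounds shown here alone, is whether an amine, a carboxylic acid or a longer alkyl chain on this aryl ring would move the number beyond the scatter. Nothing at hand explains the values seen so far.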